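Swapping methoxy for hydroxy at a measuring limit

A few compounds are considered here, and "the series" means these few. Any claim that something is new, unique, unknown or untested is made for them only; others in the source may bear on it.

Of the compounds shown here, three have so far been read in an ADME assay on HepG2 cells (Homo sapiens) for cytotoxicity, in the presence of a further agent that is not named here; on this read-out higher numbers stand for weaker inhibition and lower numbers for stronger inhibition. Compound 3 `COc1c(C(=O)NCc2ccccc2)nc(Cc2ccccc2C(F)(F)F)n(C)c1=O` gives > 100000 nM, which is a limit and not a number. Compound 1 `Cn1c(Cc2ccccc2C(F)(F)F)nc(C(=O)Nc2ccccc2)c(O)c1=O` gives > 100000 nM, again a limit. Compound 2 `Cc1nc(C(=O)NCc2ccccc2)c(O)c(=O)n1C` gives > 100000 nM, also a limit. Compound 3 therefore stands with the whole set, at the limit of > 100000 nM in this assay, at which 3 of the 3 values shown sit, and no ranking can be drawn from these readings.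

Compound 4 `Cn1c(Cc2ccccc2C(F)(F)F)nc(C(=O)NCc2ccccc2)c(O)c1=O` comes from compound 3 through a single change: hydrogen in place of methyl on an oxygen on an aromatic ring. In words, this is hydrogen in place of methyl on an oxygen on an aromatic ring, or methoxy to hydroxy. Within the data shown here, no measured pair isolates this change, so its effect in this assay has not been seen directly. A hydroxy group does occur in compound 1, whose reading is the limit > 100000 nM. It also occurs in compound 2, whose reading is the limit > 100000 nM. On that basis, no step beyond the usual scatter is expected, and the estimated change is a number no higher from compound 3 to compound 4 (the limit leaves the size open). For compound 4 the estimate is 100000 nM, with an expected range from 40000 nM to 200000 nM, and the reading may well prove to be a limit again.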

Compound 4, half-maximal inhibitory concentration: > 100000 nM
Compound 4 was reported as a limit (the forecaster's own chance of this, stated with the estimate: 85%); the middle value lies on the limit itself.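

No step from compound 1, compound 2 or compound 3 to compound 4 can be read in this assay, because every reading is a limit and not a number: the limit of > 100000 nM in this assay, at which 4 of the 4 values shown sit.

The compounds shown leave open what concentration of any of them would reach half-maximal inhibition, and whether methoxy and hydroxy differ at all on this read-out.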